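Dimethylphenyl for chlorophenyl on the triazole of compound 1

This account rests on a few compounds, and the source may have more. Where it says the series, first, only, none or still open, it means among the compounds named here.

Among the measured compounds shown here, compound 1, `N#CC1=C(N)Oc2c(c3nc4ccccc4nc3c3ccccc23)C12C(=O)N(Cc1cnnn1-c1cccc(Cl)c1)c1ccccc12`, is the only member of this small set with a measured number: in a functional assay on MCF7 cells (Homo sapiens) for antiproliferative activity, read by MTT assay, with a stated time of 48 h (on this read-out higher numbers stand for weaker inhibition and lower numbers for stronger inhibition), compound 1 gives 43600 nM, a weak result. Compound 2, `N#CC1=C(N)Oc2c(c3nc4ccccc4nc3c3ccccc23)C12C(=O)N(Cc1cnnn1-c1ccc(S(N)(=O)=O)cc1)c1ccccc12`, reaches only the limit of > 50000 nM in this assay. Compound 3, `Cc1ccc(-n2nncc2CN2C(=O)C3(C(C#N)=C(N)Oc4c3c3nc5ccccc5nc3c3ccccc43)c3ccccc32)cc1C`, likewise gives only the limit > 50000 nM in this assay. The two measured steps from compound 1 therefore read an at least 1.1-fold higher number from compound 1 to compound 2 (0.05 log units; that floor lies within the scatter) and an at least 1.1-fold higher number from compound 1 to compound 3 (0.05 log units; that floor lies within the scatter), both bounded by the limit of > 50000 nM in this assay, at which 2 of the 3 values shown sit.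

Compound 4, `Cc1cc(C)cc(-n2nncc2CN2C(=O)C3(C(C#N)=C(N)Oc4c3c3nc5ccccc5nc3c3ccccc43)c3ccccc32)c1`, differs from compound 1 by 3,5-dimethylphenyl in place of 3-chlorophenyl on an aromatic nitrogen. For the measured compounds named here, the closest measured step is the one to compound 3, an at least 1.1-fold higher number from compound 1 to compound 3 (0.05 log units; that floor lies within the scatter), which exchanged the chlorophenyl for a dimethylphenyl and ended at the limit. Compound 4 is therefore expected to sit near or beyond that same limit in this assay, with a step of a 1.5-fold higher number from compound 1 to compound 4 (0.17 log units; within the scatter) toward weaker inhibition. For compound 4 an estimated value of 65000 nM is expected, with a range from 30000 nM to 150000 nM.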

Compound 4, half-maximal inhibitory concentration: > 50000 nM
Compound 4 was reported as a limit; the forecaster's own chance of this, stated with the estimate: 65%; the middle value does not contradict the limit.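

In this assay, the change to 3,5-dimethylphenyl gives an at least 1.1-fold higher number from compound 1 to compound 4 (0.05 log units; that floor lies within the scatter), so this step, like the earlier ones, shows no difference beyond the scatter. Among the compounds shown here, what compound 4 adds is that a second dimethylphenyl pattern on this aromatic nitrogen, alongside the 3,4-dimethylphenyl of compound 3, also yields no number, leaving compound 1 as the only compound with a measured value; the steps among compounds 2, 3 and 4 cannot be read, since both ends of each are limits. The series now rests largely on one boundary: the limit of > 50000 nM in this assay, at which 3 of the 4 values shown sit.

As far as these compounds go, whether any group on this phenyl ring can bring a number clearly stronger than that of compound 1 remains open. A single methyl, a methoxy group, an amine or a carboxylic acid in the place of the chlorine could each answer that.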